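Ring-nitrogen substituents in the shared core: compound 4

The source may hold more compounds than are shown below. What is called first, only, known or untested is meant among the compounds shown, and "the series" means these compounds.

Compound 3 `COc1cccc(CN2CCC(C(=O)Nc3cc(Cl)c(N)cc3OC)CC2)c1` has so far given only a limit in a functional assay on the whole organism for antagonist activity, with Mus musculus as the target; a lower number here means that less compound is needed, a higher number that more compound is needed for the effect: in this assay compound 3 reads > 4 mg/kg, which is a limit of the assay and not a number. The two further values in the set are limits as well. Compound 1 `COc1cc(N)c(Cl)cc1NC(=O)C1CCN(C2CCCC2)CC1` carries a cyclopentyl on the amine nitrogen in the ring; in this assay compound 1 gives > 10 mg/kg, also a limit. Compound 2 `CCN1CCC(C(=O)Nc2cc(Cl)c(N)cc2OC)CC1` carries an ethyl there; in this assay compound 2 gives > 10 mg/kg, again a limit. Every step among the measured compounds is thus unreadable: a step that the two limits leave unreadable from compound 1 to compound 2, a step that the two limits leave unreadable from compound 1 to compound 3 and a step that the two limits leave unreadable from compound 2 to compound 3. The whole evidence amounts to the limit of > 10 mg/kg in this assay, at which 2 of the 3 values shown sit, and (the limit of > 4 mg/kg in this assay, at which 1 of the 3 values shown sits).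

Compound 4 `COc1cc(N)c(Cl)cc1NC(=O)C1CCN(Cc2ccc(O)cc2)CC1` differs from compound 3 in one place: 4-hydroxyphenyl in place of 3-methoxyphenyl on a saturated chain carbon bound to an amine nitrogen in a ring. Going by the values given here, no measured step bears readably on this change; the steps that alter the group on the ring nitrogen are all unreadable and give no size or direction for this assay. The expectation for compound 4 is a step that the limit leaves unreadable from compound 3 to compound 4, with the likely outcome being again a limit. Compound 4 is estimated at 10 mg/kg in this assay, with a range from 3 mg/kg to 30 mg/kg.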

Compound 4, dose for half-maximal effect: > 8 mg/kg
Compound 4: a limit, no number (the forecaster's own chance of this, stated with the estimate: 70%); the middle value lies beyond the limit too.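

In this assay compound 4 reads > 8 mg/kg, a limit of the assay and not a number, and none of its steps from compound 1, compound 2 or compound 3 can be read. The compounds shown leave open whether any group on the amine nitrogen in the ring changes the dose needed in this assay, and by how much.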